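From 4-methylphenyl to 2,4,6-trimethylphenyl in compound 4

The source may report more compounds than this note shows. Statements on the series, on what has been measured and on what is new or still open speak of the compounds shown alone.

Measured so far in a functional assay on MDA-MB-231 cells (Homo sapiens) for inhibition, read by CCK-8 assay, with a stated time of 48 h; a higher number here means a weaker inhibitor of growth, a lower number a stronger inhibitor of growth:
- Compound 1 `CN1CCN(c2ccc(Nc3ncc(Cl)c(NCc4ccc(F)cc4)n3)nc2)CC1`: > 100000 nM
- Compound 2 `CN1CCN(c2ccc(Nc3ncc(Cl)c(NCc4ccco4)n3)nc2)CC1`: 11000 nM
- Compound 3 `Cc1ccc(Nc2nc(Nc3ccc(N4CCN(C)CC4)cn3)ncc2Cl)cc1`: 4030 nM

The reading for compound 1, > 100000 nM, is a limit of the assay and not a number. Compound 3 has the lowest value of the series, 4030 nM, which makes it the strongest growth inhibitor measured so far.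

Compound 4 `Cc1cc(C)c(Nc2nc(Nc3ccc(N4CCN(C)CC4)cn3)ncc2Cl)c(C)c1` keeps the shared core and changes one group: 2,4,6-trimethylphenyl in place of 4-methylphenyl on a nitrogen on an aromatic ring. A 2,4,6-trimethylphenyl stands in place of 4-methylphenyl on a nitrogen on an aromatic ring.

Three measured changes concern the group on this nitrogen. They gave an at least 9.0-fold lower number from compound 1 to compound 2 (0.95 log units; beyond the scatter), an at least 24-fold lower number from compound 1 to compound 3 (1.39 log units; beyond the scatter) and a 2.7-fold lower number from compound 2 to compound 3 (0.44 log units; beyond the scatter). So this assay does respond to this group, but none of these steps swaps one methyl-bearing phenyl group for another, and the direction stays uncertain. Since compound 3 already sits lowest at 4030 nM, a modest rise seems likelier than a further fall. The expected change is a 1.5-fold higher number from compound 3 to compound 4 (0.17 log units; within the scatter). For compound 4 the estimated value is 6000 nM, with an expected range of 1800 nM to 25000 nM.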

Compound 4, concentration for 50% growth inhibition: 21000 nM
Compound 4: the middle estimate sits 3.5-fold (0.54 log units) below what was measured; the range from low to high includes it.
By their numbers in this assay, from the lowest: compound 3; then compounds 2 and 4 (each within the scatter of the next). At a limit, above all of these: compound 1.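

In this assay, the aromatic group on this nitrogen is not interchangeable with a more heavily methylated one: 2,4,6-trimethylphenyl in place of 4-methylphenyl gives a 5.2-fold higher number from compound 3 to compound 4 (0.72 log units; beyond the scatter), so the extra methyl groups weaken growth inhibition here. Compared with the (furan-2-yl)methyl group, the change gives a 1.9-fold higher number from compound 2 to compound 4 (0.28 log units; within the scatter), so compound 2 and compound 4 cannot be told apart, and the advantage of compound 3 over compound 2 does not extend to every phenyl group on this nitrogen. The reading for compound 1 is a limit and not a number, so an at least 4.7-fold lower number from compound 1 to compound 4 (0.67 log units; beyond the scatter) gives only a bound: the limit of > 100000 nM in this assay, at which 1 of the 4 values shown sits.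

Which of the added methyl groups accounts for the rise remains open. So does the effect of replacing the methyl group of 4-methylphenyl with an amine or a carboxylic acid.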